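Aryl swap on the core of compound 1 and solubility

The source may hold more compounds than are shown below. What is called first, only, known or untested is meant among the compounds shown, and "the series" means these compounds.

Notes on compound 1 `Cn1c(-c2cccs2)c(C2CCCCC2)c2ccc(C(=O)NC(C)(C)C(=O)Nc3ccc(/C=C/C(=O)O)cc3)cc21`, compound 2 `Cn1c(-c2ccc3ncccc3c2)c(C2CCCCC2)c2ccc(C(=O)NC(C)(C)C(=O)Nc3ccc(/C=C/C(=O)O)cc3)cc21` and the unmeasured compound 3 `COc1ccc(-c2c(C3CCCCC3)c3ccc(C(=O)NC(C)(C)C(=O)Nc4ccc(/C=C/C(=O)O)cc4)cc3n2C)cn1`. In a physicochemical assay for solubility, using the shake flask method, in phosphate buffer, with a stated time of 24 h, at pH 7.2 (on this read-out higher numbers stand for higher solubility and lower numbers for lower solubility), compound 1 gives < 0.1 ug/mL, which is a limit of the assay and not a measured number. Compound 2 gives 0.3 ug/mL in this assay. Among the measured compounds shown here, the step of an at least 3.0-fold higher number from compound 1 to compound 2 (0.47 log units; beyond the scatter) is the only measured step in the set, and its size is bounded because compound 1 sits at the limit of < 0.1 ug/mL in this assay, at which 1 of the 2 values shown sits. Compound 3 differs from compound 1 as follows: 6-methoxypyridin-3-yl in place of thiophen-2-yl on an aromatic carbon. For the measured compounds named here, no measured step carries this exact change; the nearest is an at least 3.0-fold higher number from compound 1 to compound 2 (0.47 log units; beyond the scatter), in which quinolin-6-yl replaced thiophen-2-yl on the same aromatic carbon and gave a modest rise. On that basis a modest rise in the same direction is expected for compound 3, as a step of an at least 3.0-fold higher number from compound 1 to compound 3 (0.47 log units; beyond the scatter). Compound 3 is estimated at 0.3 ug/mL in this assay, with a range from 0.1 ug/mL to 1 ug/mL. Since compound 1 rests at a limit, a further limit reading for compound 3 remains possible.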

Compound 3, solubility: 6 ug/mL
Estimate against measurement, compound 3: 20-fold (1.30 log units) below; the whole stated range lies below it.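

In this assay, the aromatic carbon next to the ring nitrogen turns out to be a far stronger handle on the read-out than the first pair suggested, with 6-methoxypyridin-3-yl in place of thiophen-2-yl giving an at least 60-fold higher number from compound 1 to compound 3 (1.77 log units; beyond the scatter). Compound 1 stands at a limit of the assay, so this step gives only a lower bound on the size of the change: the limit of < 0.1 ug/mL in this assay, at which 1 of the 3 values shown sits.

The step with a fully measured size is a 20-fold higher number from compound 2 to compound 3 (1.30 log units; beyond the scatter), with 6-methoxypyridin-3-yl in place of quinolin-6-yl, which shows that at this one carbon the choice between two six-membered aromatic groups, each carrying a ring nitrogen, separates the compounds by well beyond the scatter.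

The compounds shown leave open which part of 6-methoxypyridin-3-yl goes with the higher number, the ring nitrogen or the methoxy group, and an unsubstituted pyridin-3-yl beside a methoxyphenyl would separate the two. They also leave open whether the same replacement holds its size when the cyclohexyl group on the neighbouring ring atom gives way to a smaller ring or an open chain.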